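Switching the ring on the aniline: pyrrolidinyl to methylpiperidinyl

The compounds below may be only part of what the source reports. "The series", "measured", "known", "first", "only" and "open" are said of these compounds alone.

Compound 2 `CCC(=O)Nc1cccc(Oc2nc(Nc3ccc(N4CCCC4)cc3OC)ncc2Cl)c1` gives 25.8% in an assay on isolated protein for inhibition of NUAK family SNF1-like kinase 1 (Homo sapiens), read by ADP-Glo, with a stated time of 60 min, tested at 10 uM, in the presence of a further agent that is not named here (on this read-out higher numbers stand for more inhibition at the one concentration tested (going by the name of the read-out) and lower numbers for less inhibition), the higher of the two numbers in hand; compound 1 `CCC(=O)Nc1cccc(Oc2nc(Nc3ccc(N4CCC(OC)CC4)cc3OC)ncc2Cl)c1` gives 5.08%. Within the data shown here, the one step known, a number 20.7 percentage points higher from compound 1 to compound 2 (beyond the scatter), came from swapping a six-membered ring for a five-membered one. Compound 3 `CCC(=O)Nc1cccc(Oc2nc(Nc3ccc(N4CCC(C)CC4)cc3OC)ncc2Cl)c1` reverses part of that: 4-methylpiperidin-1-yl in place of pyrrolidin-1-yl on an aromatic carbon. Among the measured compounds shown here, the ring entering is six-membered like that of compound 1, yet carries a methyl rather than a methoxy group, so the single step only partly applies. The step expected is a number 12.8 percentage points lower from compound 2 to compound 3 (beyond the scatter), a drop toward compound 1, though an uncertain one. Compound 3 is estimated at 13%, between 0% and 32%.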

Compound 3, a percentage reported as inhibition, at one concentration (the size of the read-out at that concentration, not a potency): 9.2%
Estimate against measurement, compound 3: 3.8 percentage points above; the range from low to high includes it.
By their numbers in this assay, from the lowest: compounds 1 and 3 (each within the scatter of the next); then compound 2.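

The advantage of pyrrolidin-1-yl now holds against a second six-membered ring, since 4-methylpiperidin-1-yl gives a number 16.6 percentage points lower from compound 2 to compound 3 (beyond the scatter) and the first comparison was with a methoxy-bearing ring. Methyl and methoxy on that ring cannot be told apart, with a number 4.1 percentage points higher from compound 1 to compound 3 (within the scatter) so the methoxy group alone does not account for the lower number of compound 1. No measurement in hand explains these differences.

Ring size and the presence of a ring substituent remain tangled together. Plain piperidin-1-yl, or morpholin-4-yl with its ring oxygen, would be needed to separate them.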